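Shortening the Amide Chain: From Compound 1 to Compound 3

The source may report more compounds than this note shows. Statements on the series, on what has been measured and on what is new or still open speak of the compounds shown alone.

Compound 1 `COc1cc2cc(C(=O)NCCCc3ccccc3)c(=O)oc2cc1OCCCOc1no[n+]([O-])c1S(=O)(=O)c1ccccc1` gives 760 nM in a functional assay on MDA-MB-231 cells (Homo sapiens) for inhibition, read by MTT assay, with a stated time of 48 h (on this read-out higher numbers stand for weaker inhibition and lower numbers for stronger inhibition), the higher of the two measured numbers, though its gap to compound 2 is within the scatter. Compound 2 `COc1cc2cc(C(=O)NCCCc3ccc(F)cc3)c(=O)oc2cc1OCCCOc1no[n+]([O-])c1S(=O)(=O)c1ccccc1` gives 690 nM in this assay, a step of a 1.1-fold lower number from compound 1 to compound 2 (0.04 log units; within the scatter). Compound 3 `COc1cc2cc(C(=O)NCc3ccccc3)c(=O)oc2cc1OCCCOc1no[n+]([O-])c1S(=O)(=O)c1ccccc1` differs from compound 1 by phenyl in place of phenethyl on a saturated chain carbon bound to an amide-type nitrogen. For the measured compounds named here, the only measured step swaps an aromatic hydrogen for fluoro; it does not touch the chain and so says nothing about this change. Compound 3 is therefore expected near 900 nM, with a range of 350 nM to 2500 nM. That estimate means a step of a 1.2-fold higher number from compound 1 to compound 3 (0.07 log units; within the scatter).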

Compound 3, half-maximal inhibitory concentration: 1060 nM
Compound 3: middle estimate off by 1.2-fold (0.07 log units), on the low side; measured number inside the range.
By their numbers in this assay, from the lowest: compounds 2, 1 and 3 (each within the scatter of the next).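

Shortening the amide chain from 3-phenylpropyl to benzyl gives a 1.4-fold higher number from compound 1 to compound 3 (0.14 log units; within the scatter) and, with the fluoro compound as the starting point, a 1.5-fold higher number from compound 2 to compound 3 (0.19 log units; within the scatter) in this assay. So at this position, the two chain lengths shown cannot be told apart on this read-out, even though the phenyl ring sits closer to the amide nitrogen. No supporting measurement bears on this result.

On these data alone, whether a longer chain such as 5-phenylpentyl would stay within this range remains open. So does what would happen if an amine or a carboxylic acid replaced the terminal phenyl.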